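Swapping a carbamoylmethyl for a nitrophenyl on the ring nitrogen

The compounds below may be only part of what the source reports. "The series", "measured", "known", "first", "only" and "open" are said of these compounds alone.

Of the compounds shown here, three built on one shared core have been tested in a functional assay on DU-145 cells (Homo sapiens) for inhibition, read by MTT assay, with a stated time of 24 h; on this read-out lower numbers stand for stronger inhibition and higher numbers for weaker inhibition. Compound 1 `CCOC(=O)C1=Cc2ccccc2OC1(OCc1cn(-c2ccc(F)cc2)nn1)C(F)(F)F` gives 8900 nM. Compound 2 `CCCCCCCCn1cc(COC2(C(F)(F)F)Oc3ccccc3C=C2C(=O)OCC)nn1` reaches only a limit of the assay, > 150000 nM. Compound 3 `CCOC(=O)C1=Cc2ccccc2OC1(OCc1cn(CC(=O)Nc2ccccc2F)nn1)C(F)(F)F` gives 33900 nM, which is the highest of the two plain numbers; its nearest neighbour is compound 1, and the step of a 3.8-fold higher number from compound 1 to compound 3 (0.58 log units; beyond the scatter) separates them. The step of an at least 16-fold higher number from compound 1 to compound 2 (1.22 log units; beyond the scatter) is the other change at the same nitrogen that has a number attached.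

Compound 4 `CCOC(=O)C1=Cc2ccccc2OC1(OCc1cn(-c2ccc([N+](=O)[O-])cc2)nn1)C(F)(F)F` has not yet been measured. It differs from compound 3 in one place: 4-nitrophenyl in place of ((2-fluorophenyl)carbamoyl)methyl on an aromatic nitrogen. The change brings an aromatic ring directly onto that ring nitrogen, as in compound 1, and so the measured step of a 3.8-fold higher number from compound 1 to compound 3 (0.58 log units; beyond the scatter) is the one that bears on it, read in reverse. A modest step downward is therefore expected, a 3.8-fold lower number from compound 3 to compound 4 (0.58 log units; beyond the scatter). Compound 4 is expected to give about 9000 nM, with a range from 3000 nM to 30000 nM.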

Compound 4, half-maximal inhibitory concentration: > 150000 nM
Compound 4: a limit, no number (the forecaster's own chance of this, stated with the estimate: 10%); middle value at least 16-fold (1.22 log units) away from the limit.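

Changing a single group on the aromatic ring at this nitrogen is enough to lose the measurable effect: with nitro in place of fluoro there is an at least 16-fold higher number from compound 1 to compound 4 (1.22 log units; beyond the scatter). An aromatic ring directly on the ring nitrogen therefore does not by itself give the stronger result, and the comparison with the carbamoylmethyl side chain now depends on the group that ring carries, with compound 1 ahead of compound 3 but an at least 4.4-fold higher number from compound 3 to compound 4 (0.64 log units; beyond the scatter). The value of compound 4 is only a limit of the assay, as is that of compound 2, so the step between these two cannot be read: the limit of > 150000 nM in this assay, at which 2 of the 4 values shown sit.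

As far as these compounds go, what an amine or a carboxylic acid would give in place of the fluoro on the phenyl ring remains open. So does the result for a chain shorter than octyl on the ring nitrogen.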